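The source may hold more compounds than are shown below. What is called first, only, known or untested is meant among the compounds shown, and "the series" means these compounds.

Working notes on the series

The series is built on one shared core, carried by compound 1 `O=C(CSc1nccn1-c1ccc(Cl)cc1)Nc1ccccc1F`, compound 2 `Cc1ccc(-n2ccnc2SCC(=O)Nc2ccccc2Cl)cc1`, compound 3 `Cc1ccc(-n2ccnc2SCC(=O)Nc2ccccc2F)cc1` and the not yet measured compound 4 `O=C(CSc1nccn1-c1ccc(Cl)cc1)Nc1ccccc1Cl`. In an ADME assay on MT4 cells (Homo sapiens) for cytotoxicity, read by MTT assay (a lower number here means that less compound is tolerated, a higher number that more compound is tolerated), compound 2 gives 33700 nM and compound 3 gives 37900 nM; the two lie within the scatter, a 1.1-fold higher number from compound 2 to compound 3 (0.05 log units; within the scatter). For compound 1 only a limit is reported in this assay, > 345000 nM; see (the limit of > 345000 nM in this assay, at which 1 of the 3 values shown sits). The change from compound 3 to compound 1 is chloro in place of methyl on an aromatic carbon, and it gives an at least 9.1-fold higher number from compound 3 to compound 1 (0.95 log units; beyond the scatter).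

Compound 4 arises from compound 2 by the same change, (chloro in place of methyl on an aromatic carbon); the place is described in the same words for both pairs, so the two steps are taken as the same change. The two starting cores differ as chloro in place of fluoro on an aromatic carbon, and that difference is within the scatter in this assay.

From compound 2 to compound 4 a step of about a 9.8-fold higher number from compound 2 to compound 4 (0.99 log units; beyond the scatter) in this assay is therefore expected, resting on the step seen from compound 3 to compound 1, an at least 9.1-fold higher number from compound 3 to compound 1 (0.95 log units; beyond the scatter). For compound 4 a value of roughly 330000 nM is estimated in this assay, between 120000 nM and 1000000 nM, with a fair chance that only a limit is reported.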

Compound 4, half-maximal cytotoxic concentration: > 330000 nM
Compound 4: only a limit was reported; the forecaster's own chance of this, stated with the estimate: 60%; the middle value sits exactly at the limit.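

Going from 4-methylphenyl to 4-chlorophenyl gives an at least 9.7-fold higher number from compound 2 to compound 4 (0.99 log units; beyond the scatter) in this assay, so the change moves the number upward, beyond the scatter, on both cores shown: the same change on two cores in this assay, an at least 9.1-fold higher number (0.95 log units; beyond the scatter) from compound 3 to compound 1 and an at least 9.7-fold higher number (0.99 log units; beyond the scatter) from compound 2 to compound 4; the limit leaves it open whether they differ

From the compounds shown here alone, for compound 4 the reading is a limit, > 330000 nM, and not a number, so the direction of the change carries from one core to the other while its full size stays unknown on both. The step between compound 1 and compound 4 cannot be read, and two cores alone do not show that the change would carry to any core beyond these.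

The compounds shown leave open how the number would move with a methoxy group, an amine or a carboxylic acid in the place of the methyl. Also open, going by these compounds, is the actual value of compound 1 and compound 4, which are known only as limits in this assay.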